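Moving a Methyl Around the Ring: Expected Solubility

The compounds below may be only part of what the source reports. "The series", "measured", "known", "first", "only" and "open" are said of these compounds alone.

Measured so far:
compound 1 `C[C@@H](Nc1c(NCCCCCC(=O)NO)c(=O)c1=O)c1ccccc1` gives 39000000 nM in a physicochemical assay for solubility, with a stated time of 24 h, tested at 30 mg/mL; on this read-out lower numbers stand for lower solubility and higher numbers for higher solubility
compound 2 `C[C@H](Nc1c(NCCCCCC(=O)NO)c(=O)c1=O)c1ccccc1` gives 28000000 nM in this assay
compound 3 `Cc1ccccc1[C@H](C)Nc1c(NCCCCCC(=O)NO)c(=O)c1=O` gives 47000000 nM in this assay

Compound 4 `Cc1cccc([C@@H](C)Nc2c(NCCCCCC(=O)NO)c(=O)c2=O)c1` is not yet measured. It differs from compound 1 by methyl in place of hydrogen on an aromatic carbon. The same kind of change already exists between compound 2 and compound 3, namely (methyl in place of hydrogen on an aromatic carbon), and there it made a 1.7-fold higher number from compound 2 to compound 3 (0.22 log units; within the scatter). The two changes are of the same kind, not the same: in compound 3 the methyl sits ortho to a large group, in compound 4 meta to a large group. The cores of compound 1 and compound 2 differ by the two compounds have the same atoms and bonds and differ only in configuration as drawn: 1 of 1 stereo elements differ; a stereocentre at a saturated chain carbon is drawn S in compound 2 and R in compound 1, and their values lie within the scatter because of the fact that compounds 1 and 2 differ only in the configuration as drawn.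

From compound 1 to compound 4 a step of a 1.4-fold higher number from compound 1 to compound 4 (0.15 log units; within the scatter) is expected, resting on a 1.7-fold higher number from compound 2 to compound 3 (0.22 log units; within the scatter). Compound 4 is therefore estimated at 55000000 nM, between 25000000 nM and 120000000 nM.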

Compound 4, solubility: 82000000 nM
Compound 4: the middle estimate sits 1.5-fold (0.17 log units) below what was measured, within the range that was stated.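

In this assay, methyl in place of hydrogen on an aromatic carbon gives a 2.1-fold higher number from compound 1 to compound 4 (0.32 log units; beyond the scatter), while the same kind of change on the other core gives a 1.7-fold higher number from compound 2 to compound 3 (0.22 log units; within the scatter). Only the first of these steps lies beyond the scatter, so the change has a modest measured effect on the core of compound 1 but does not show that this effect carries over to the other core. The two steps differ in the methyl's place as well as in the core, with compound 4 carrying it meta to a large group and compound 3 not, so the two influences cannot be separated, and what separates the cores is this: the fact that compounds 1 and 2 differ only in the configuration as drawn

The compounds shown leave open how a methyl meta to a large group would behave on the core of compound 2. They also leave open how an amine or a carboxylic acid on that ring would compare with methyl.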